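Series notes: 6-methylpyridin-2-yl in place of piperidin-1-yl

The compounds below may be only part of what the source reports. "The series", "measured", "known", "first", "only" and "open" are said of these compounds alone.

Measured so far:
compound 1 `c1ccc(-c2ccc(CCc3nc(CC4CCCC4)c[nH]3)cc2)nc1` — 98 nM
compound 2 `CCC(C)(C)Cc1c[nH]c(CCc2ccc(N3CCCCC3)cc2)n1` — 108 nM

In a functional assay on HEK293 cells for agonist activity at Bombesin receptor subtype-3 (Homo sapiens), read by luminescence and calcium flux, with a stated time of 10 min (on this read-out lower numbers stand for an effect already at smaller amounts and higher numbers for an effect only at larger amounts of compound), compound 1 gives 98 nM. In the same read-out compound 2 gives 108 nM. Compound 2 holds the higher of the two numbers, but its gap to compound 1 lies within the scatter, so the two cannot be ranked.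

Compound 3 `CCC(C)(C)Cc1c[nH]c(CCc2ccc(-c3cccc(C)n3)cc2)n1` differs from compound 2 in one place: 6-methylpyridin-2-yl in place of piperidin-1-yl on an aromatic carbon. For the measured compounds named here, no measured pair carries this exact change. Compound 1, whose number sits within the scatter of compound 2, already bears a six-membered aromatic ring with one hetero atom on the aromatic carbon in question, in place of the non-aromatic ring of compound 2. The step from compound 2 to compound 3 is therefore expected to be small, without a clear direction beyond the scatter, as a 1.1-fold lower number from compound 2 to compound 3 (0.03 log units; within the scatter). Compound 3 is estimated at 100 nM, with a range from 40 nM to 250 nM.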

Compound 3, half-maximal effective concentration: 102 nM
For compound 3 the middle estimate is 1.0-fold (0.01 log units) below the measured one; the range from low to high includes it.
By their numbers in this assay, from the lowest: compounds 1, 3 and 2 (each within the scatter of the next).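

In this assay, 6-methylpyridin-2-yl in place of piperidin-1-yl on an aromatic carbon, para to a large group, gives a 1.1-fold lower number from compound 2 to compound 3 (0.02 log units; within the scatter). For the compounds shown here, this is the first single-place comparison: with the rest of compound 2 held constant, a six-membered non-aromatic ring and a six-membered aromatic ring, each with 1 hetero atom, cannot be told apart at this position, something compound 1 could not show, as it differs from compound 2 in more than one place. No measurement at hand accounts for this result.

Open, going by these compounds, is whether a group other than a six-membered ring, such as a carboxylic acid or a primary amine, would keep the number in this range on the same aromatic carbon. Also open, on these data alone, is whether the methyl group of 6-methylpyridin-2-yl matters at all.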